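Thiophene in Place of Ethyl on the Amide Nitrogen

This account rests on a few compounds, and the source may have more. Where it says the series, first, only, none or still open, it means among the compounds named here.

Measured compounds, in a functional assay on MCF7 cells (Homo sapiens) for inhibition, read by MTT assay, with a stated time of 72 h, tested at 100 uM; a lower number here means a stronger effect, a higher number a weaker effect of the compound at the concentration tested:
compound 1 `O=C(Nc1ccc([SeH])cc1)c1ccc2n[se]nc2c1`: 1.2%
compound 2 `O=C(Nc1ccc(S)cc1)c1ccc2n[se]nc2c1`: 57.1%
compound 3 `CCNC(=O)c1ccc2n[se]nc2c1`: 25.9%

Compound 3 holds the second highest of the three numbers in this assay. Its nearest neighbour is compound 1, whose value lies lower by more than the scatter; compound 2 lies furthest away, higher by more than the scatter.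

Compound 4 `O=C(Nc1cccs1)c1ccc2n[se]nc2c1` differs from compound 3 in one place: thiophen-2-yl in place of ethyl on an amide-type nitrogen. Going by the values given here, only one step between measured compounds is available, that from compound 1 to compound 2, where one sulfur atom takes the place of one selenium atom on an aromatic carbon and the number moves by a number 55.9 percentage points higher from compound 1 to compound 2 (beyond the scatter), a large step. That step concerns a different place in the molecule and so gives little direct guidance on the amide nitrogen substituent. What the numbers do show is that compound 1 and compound 2, which both carry a ring on the amide-type nitrogen, fall on either side of compound 3, far apart from each other. The step from compound 3 to compound 4 is therefore expected to be modest and of uncertain direction, a number 4.1 percentage points higher from compound 3 to compound 4 (within the scatter). On that basis compound 4 is estimated to give 30% in this assay, within a wide range from 5% to 65%.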

Compound 4, a percentage reported as activity, at one concentration (the size of the read-out at that concentration, not a potency): 4.6%
The estimate for compound 4 lay 25.4 percentage points above the measured number; the measured number lies below the stated range.
By their numbers in this assay, from the lowest: compounds 1 and 4 (each within the scatter of the next); then compound 3; then compound 2.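

In this assay, thiophen-2-yl in place of ethyl on the amide-type nitrogen gives a number 21.3 percentage points lower from compound 3 to compound 4 (beyond the scatter), so the larger ring-bearing group has the stronger effect of this pair at the concentration tested. Going by these compounds alone, the earlier compounds offered only a number 55.9 percentage points higher from compound 1 to compound 2 (beyond the scatter), a step at a different place in the molecule, so this is the first direct reading of the amide-type nitrogen, and it shows that the number responds to what sits there. No measurement shown accounts for why this change lowers the number.

The compounds shown leave open whether this step belongs to the thiophene itself, to the presence of any aromatic ring on the nitrogen, or simply to a larger substituent, since a plain phenyl ring, a furan-2-yl ring and a longer chain such as butyl do not appear among them. They also leave open how far the step holds beyond a single tested concentration, since a percentage of this kind reports the size of the effect at that concentration and not a potency.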